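This account rests on a few compounds, and the source may have more. Where it says the series, first, only, none or still open, it means among the compounds named here.

Of the compounds shown here, three have so far been tested in a functional assay on HepG2 cells (Homo sapiens) for antiproliferative activity, read by MTT assay, with a stated time of 72 h; a lower number here means a stronger inhibitor, a higher number a weaker inhibitor. Compound 1 `FC(F)(F)c1ccc(COc2ccccc2Nc2ncnc3cc4c(cc23)OCCOCCOCCO4)cc1` gives > 100000 nM, which is a limit of the assay and not a number. Compound 3 `O=[N+]([O-])c1ccc(COc2ccc(Nc3ncnc4cc5c(cc34)OCCOCCOCCOCCO5)cc2)cc1` gives > 100000 nM, which is also a limit and not a number. Going by the values given here, compound 2 `FC(F)(F)c1ccc(COc2cccc(Nc3ncnc4cc5c(cc34)OCCOCCOCCO5)c2)cc1` gives 34000 nM, the only true number among the three, so it is the natural starting point for any comparison.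

The next molecule, compound 4 `c1ccc(COc2cccc(Nc3ncnc4cc5c(cc34)OCCOCCOCCO5)c2)cc1`, has not yet been measured. It differs from compound 2 in one place: hydrogen stands in place of trifluoromethyl on an aromatic carbon, para to a large group, so that 4-(trifluoromethyl)benzyl becomes benzyl (hydrogen in place of trifluoromethyl on an aromatic carbon).

Among the compounds with values here, no two tested compounds differ in just one place, so the data give no direct measure of what this change does. The expectation is therefore a small step towards weaker activity, perhaps none beyond the scatter. It leans to the weak side because of the limit of > 100000 nM in this assay, at which 2 of the 3 values shown sit. The estimated change is a 1.5-fold higher number from compound 2 to compound 4 (0.17 log units; within the scatter). In this assay the estimated value for compound 4 is 50000 nM, with an expected range of 20000 nM to 100000 nM.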

Compound 4, half-maximal inhibitory concentration: > 100000 nM
Compound 4 gave a limit, no number; the forecaster's own chance of this, stated with the estimate: 30%; middle value at least 2.0-fold (0.30 log units) away from the limit.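

Hydrogen in place of trifluoromethyl on an aromatic carbon, para to a large group, gives an at least 2.9-fold higher number from compound 2 to compound 4 (0.46 log units; beyond the scatter) in this assay, and this is the first comparison in the series between two compounds that differ in only one place. It shows that the measurable antiproliferative activity of compound 2 depends on what sits at this position: with trifluoromethyl there the assay returns a true number, while with hydrogen it returns only a limit. The step is therefore a minimum and not a full size, because the true value of compound 4 cannot be read beyond the end of the scale: the limit of > 100000 nM in this assay, at which 3 of the 4 values shown sit.

Going by these compounds, with only hydrogen and trifluoromethyl compared at this carbon, it remains open whether trifluoromethyl itself is needed or whether other groups there would serve as well. A chlorine atom, a methoxy group, a nitrile or an amine on the same carbon would help to separate these possibilities, and a number for any of them would show how far activity at this position can move from the value of compound 2.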